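Aryl swap on the shared core: methoxy for methyl

The source may report more compounds than this note shows. Statements on the series, on what has been measured and on what is new or still open speak of the compounds shown alone.

For the measured compounds named here, the series so far: compound 1 `CCc1nc(Nc2cccnc2Oc2ccccc2C(C)(C)C)sc1-c1ccccc1`, compound 2 `CCOC(=O)c1sc(Nc2cccnc2Oc2ccccc2C(C)(C)C)nc1C(F)(F)F` and compound 3 `Cc1ccccc1-c1sc(Nc2cccnc2Oc2ccccc2C(C)(C)C)nc1C(F)(F)F`, all carrying the same aminopyridine ether arm. In an assay on HEK293 cells for displacement of a labelled ligand from P2Y purinoceptor 1 (Homo sapiens), read by scintillation counting, with a stated time of 1 h (a lower number here means a stronger inhibitor, a higher number a weaker inhibitor), compound 1 gives 12 nM, compound 2 gives 5 nM and compound 3 gives 11 nM. Going by the values given here, compound 3 therefore sits second highest of the three numbers; its gap to compound 1 lies within the scatter, while a 2.2-fold higher number from compound 2 to compound 3 (0.34 log units; beyond the scatter) marks the only step that clears it.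

Compound 4 `COc1ccc(-c2sc(Nc3cccnc3Oc3ccccc3C(C)(C)C)nc2C(F)(F)F)cc1` is next: 4-methoxyphenyl in place of 2-methylphenyl on an aromatic carbon. Among the compounds with values here, no measured step alters the substitution pattern of the aryl group; the one recorded step swaps a whole group class, and compound 1 differs from compound 3 in two places, so only their two values can be compared, and those sit within the scatter of each other. The expectation for this assay is accordingly a step of a 1.1-fold higher number from compound 3 to compound 4 (0.04 log units; within the scatter), no change beyond the scatter, in either direction.

Compound 4 is estimated at 12 nM, with a range from 5 nM to 30 nM.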

Compound 4, inhibition constant: 8 nM
Beside the measured number, compound 4's estimate is 1.5-fold (0.18 log units) above it; the range from low to high includes it.
By their numbers in this assay, from the lowest: compounds 2, 4, 3 and 1 (each within the scatter of the next, the first and the last beyond it).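

In this assay, replacing 2-methylphenyl with 4-methoxyphenyl on the aromatic carbon next to the ring sulfur gives a 1.4-fold lower number from compound 3 to compound 4 (0.14 log units; within the scatter), so a change in both the substituent and its place on the phenyl ring is not resolved from no change. The ethoxycarbonyl group stood clear of the scatter against 2-methylphenyl, but against 4-methoxyphenyl the same position gives a 1.6-fold higher number from compound 2 to compound 4 (0.20 log units; within the scatter), so that separation holds for only one of the two aryl groups. No evidence bears on the reason for these numbers.

The swap alters the substituent and its place together, so their separate contributions remain unresolved. Also open, going by these compounds, is whether a carboxylic acid or an aminomethyl group on the phenyl ring, or a cyclohexyl group in place of it, would keep the number in this range.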